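The source may report more compounds than this note shows. Statements on the series, on what has been measured and on what is new or still open speak of the compounds shown alone.

Working notes on the series. In an assay for inhibition of serine/threonine-protein kinase Sgk1 (Homo sapiens), with stated times of 30 min and 60 min, in the presence of a further agent that is not named here (on this read-out higher numbers stand for weaker inhibition and lower numbers for stronger inhibition), compound 1 `Cc1n[nH]c2nc(-c3ccc(NS(=O)(=O)c4cc(Cl)ccc4F)cc3)nc(OCCC(=O)N(C)C)c12` gives 438 nM. Compound 2 `Cc1n[nH]c2nc(-c3ccc(NS(=O)(=O)c4cc(Cl)ccc4F)cc3)nc(OCC3(CN)COC3)c12` gives 1 nM. Compound 3 `Cc1n[nH]c2nc(-c3ccc(NS(=O)(=O)c4cc(Cl)ccc4F)cc3)nc(OC3CCC(=O)CC3)c12` gives 18 nM, the second highest of the three numbers, set by an 18-fold higher number from compound 2 to compound 3 (1.26 log units; beyond the scatter) and a 24-fold lower number from compound 1 to compound 3 (1.39 log units; beyond the scatter). The change to compound 4 `Cc1n[nH]c2nc(-c3ccc(NS(=O)(=O)c4cc(Cl)ccc4F)cc3)nc(OCC3CN(C(C)C)C3)c12` is (1-isopropylazetidin-3-yl)methyl in place of 4-oxocyclohexyl on an oxygen on an aromatic ring. The step of an 18-fold higher number from compound 2 to compound 3 (1.26 log units; beyond the scatter) bears on it most: the entering group of compound 4, like that of compound 2, carries a nitrogen, while the oxocyclohexyl is removed. The step of a 440-fold lower number from compound 1 to compound 2 (2.64 log units; beyond the scatter) points the same way. A lower number is therefore expected, roughly a 4.5-fold lower number from compound 3 to compound 4 (0.65 log units; beyond the scatter), though the different ring size and the isopropyl on the nitrogen leave the full return to the level of compound 2 uncertain. Compound 4 is estimated at 4 nM, range 1 nM to 20 nM.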

Compound 4, half-maximal inhibitory concentration: 1 nM
The estimate for compound 4 lay 4.0-fold (0.60 log units) above the measured number, within the range that was stated.
By their numbers in this assay, from the lowest: compounds 2 and 4 (each within the scatter of the next); then compound 3; then compound 1.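

In this assay a second nitrogen-carrying group on the oxygen gives an 18-fold lower number from compound 3 to compound 4 (1.26 log units; beyond the scatter), and a 440-fold lower number from compound 1 to compound 4 (2.64 log units; beyond the scatter), so the low number no longer rests on compound 2 alone. The 1-isopropylazetidin-3-yl and 3-(aminomethyl)oxetan-3-yl groups cannot be told apart here, with no change at the digits printed from compound 2 to compound 4 (within the scatter), even though they differ in ring hetero atom and in where the nitrogen sits. No measurement on hand explains these steps. The compounds shown leave open whether the nitrogen is required, which a cyclobutylmethyl group would test, and whether an open-chain 2-(dimethylamino)ethyl group would serve as well as a ring.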